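Capping the Phenol of Compound 3 with a Sulfonyl Ester

A few compounds are considered here, and "the series" means these few. Any claim that something is new, unique, unknown or untested is made for them only; others in the source may bear on it.

Measured so far:
compound 1 `C=C1C(=O)[C@]23C[C@@]1(O)CC[C@H]2c1ccc(OS(=O)(=O)c2ccc(C)cc2)c(C)c1[C@@H]3Cn1cc(-c2ccc(Br)cc2)nn1`: 4320 nM
compound 2 `C=C1C(=O)[C@]23C[C@@]1(O)CC[C@H]2c1ccc(OS(=O)(=O)c2ccc(C)cc2)c(C)c1[C@@H]3Cn1cc(-c2ccc(F)cc2)nn1`: 4280 nM
compound 3 `C=C1C(=O)[C@]23C[C@@]1(O)CC[C@H]2c1ccc(O)c(C)c1[C@@H]3Cn1cc(-c2ccc(OC)cc2)nn1`: 860 nM

In a functional assay on SMMC-7721 cells (Homo sapiens) for cytotoxicity, read by MTT assay, with a stated time of 4 days (a higher number here means a weaker inhibitor, a lower number a stronger inhibitor), compound 3 gives the lowest number of the three, with compound 1 and compound 2 both well beyond the scatter above it. Compound 4 `C=C1C(=O)[C@]23C[C@@]1(O)CC[C@H]2c1ccc(OS(=O)(=O)c2ccc(C)cc2)c(C)c1[C@@H]3Cn1cc(-c2ccc(OC)cc2)nn1` differs from compound 3 by (4-methylphenyl)sulfonyl in place of hydrogen on an oxygen on an aromatic ring. For the measured compounds named here, the only measured step, a 1.0-fold lower number from compound 1 to compound 2 (0.00 log units; within the scatter), concerns the halogen and says nothing about this change. Still, compound 1 and compound 2 both carry the same sulfonyl ester and both sit far above compound 3, so a weaker inhibitor is expected. The expected step is a 3.5-fold higher number from compound 3 to compound 4 (0.54 log units; beyond the scatter). Compound 4 is therefore estimated at 3000 nM, with a range from 1200 nM to 7500 nM.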

Compound 4, half-maximal inhibitory concentration: 1720 nM
The estimate for compound 4 lay 1.7-fold (0.24 log units) above the measured number; low and high end bracket the measured number.
By their numbers in this assay, from the lowest: compounds 3 and 4 (each within the scatter of the next); then compounds 2 and 1 (each within the scatter of the next).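

In this assay, (4-methylphenyl)sulfonyl in place of hydrogen on this oxygen gives a 2.0-fold higher number from compound 3 to compound 4 (0.30 log units; within the scatter), so this large cap is not clearly separated from the free hydroxy. With the cap present, the group on the other aromatic ring does register, as methoxy in place of fluoro gives a 2.5-fold lower number from compound 2 to compound 4 (0.40 log units; beyond the scatter) and methoxy in place of bromo gives a 2.5-fold lower number from compound 1 to compound 4 (0.40 log units; beyond the scatter). No measurement shown explains these steps. As far as these compounds go, whether a methyl ether or an acetyl ester on this oxygen would behave alike remains open. So does whether methoxy keeps this edge over the halogens when the hydroxy is free.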